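Swapping the indazole for a benzothiazole on the stilbene core

The compounds below may be only part of what the source reports. "The series", "measured", "known", "first", "only" and "open" are said of these compounds alone.

Compound 1 `CC/C(=C(/c1ccc(/C=C/C(=O)O)cc1)c1ccc2[nH]ncc2c1)c1ccccc1`: 7.2 nM
Compound 2 `CC/C(=C(/c1ccc(/C=C/C(=O)O)cc1)c1ccc2nncn2c1)c1ccccc1`: > 500 nM
Compound 3 `CC/C(=C(/c1ccc(/C=C/C(=O)O)cc1)c1ccc2nnnn2c1)c1ccccc1`: > 500 nM

Among the compounds with values here, in a functional assay on MCF7 cells (Homo sapiens) for antiproliferative activity, read by CellTiter-Glo, with a stated time of 5 days (on this read-out higher numbers stand for weaker inhibition and lower numbers for stronger inhibition), compound 1 gives 7.2 nM and is the only compound of the three that gives a number rather than a limit. For compound 2 the value > 500 nM is a limit of this assay. For compound 3 the value > 500 nM is likewise a limit. Both replacements of the 1H-indazol-5-yl group cost heavily: an at least 69-fold higher number from compound 1 to compound 2 (1.84 log units; beyond the scatter) and an at least 69-fold higher number from compound 1 to compound 3 (1.84 log units; beyond the scatter), each at the limit of > 500 nM in this assay, at which 2 of the 3 values shown sit. Between compounds 2 and 3 the two limits leave the step unreadable.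

Compound 4 `CC/C(=C(/c1ccc(/C=C/C(=O)O)cc1)c1ccc2ncsc2c1)c1ccccc1` carries the change (1,3-benzothiazol-6-yl in place of 1H-indazol-5-yl on a double-bonded chain carbon bound to an aromatic carbon and a double-bonded chain carbon). Unlike compounds 2 and 3, compound 4 keeps one six-membered aromatic ring of carbon only and a five-membered aromatic ring with 2 hetero atoms, so the steps from compound 1 to compounds 2 and 3 bear on it only in part. Compound 4 is therefore expected to lose some potency relative to compound 1 but to remain measurable: the estimated step is a 5.6-fold higher number from compound 1 to compound 4 (0.74 log units; beyond the scatter). For compound 4 the estimate in this assay is 40 nM, within 8 nM to 400 nM.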

Compound 4, half-maximal inhibitory concentration: > 500 nM
Compound 4: only a limit was reported; the forecaster's own chance of this, stated with the estimate: 15%; at least 12-fold (1.09 log units) between middle value and limit.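

In this assay compound 4 gives > 500 nM, which is a limit and not a number, and it joins the other compounds there: the limit of > 500 nM in this assay, at which 3 of the 4 values shown sit.

The step is an at least 69-fold higher number from compound 1 to compound 4 (1.84 log units; beyond the scatter), so at this place, on a double-bonded chain carbon bound to an aromatic carbon and a double-bonded chain carbon, keeping a six-membered aromatic ring of carbon only and a five-membered aromatic ring with 2 hetero atoms does not keep the activity of compound 1, which compounds 2 and 3 could not show, as both carry a six-membered aromatic ring with 1 hetero atom; in the counts, 1,3-benzothiazol-6-yl differs from 1H-indazol-5-yl by a sulfur in place of a nitrogen and by 0 hydrogen-bond donors in place of 1. The steps from compounds 2 and 3 to compound 4 cannot be read, as both ends of each are limits.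

The compounds shown do not separate the loss of the ring nitrogen-hydrogen from the entry of sulfur. Nor do they tell how a hydroxyl or an amine on the carbon-only six-membered ring would fare at this place, or how far above the limit compounds 2, 3 and 4 lie.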